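The source may hold more compounds than are shown below. What is called first, only, known or untested is meant among the compounds shown, and "the series" means these compounds.

Measured compounds:
- compound 1, `Cc1nnc2nnc(N3CCCC3)nn12`, gives 44800 nM in a functional assay on MCF7 cells (Homo sapiens) for cytotoxicity, read by MTT assay, with a stated time of 72 h; on this read-out lower numbers stand for stronger inhibition and higher numbers for weaker inhibition.
- compound 3, `C1CCC(c2nnc3nnc(N4CCCC4)nn23)CC1`, gives 37700 nM in this assay.
- compound 2, `Fc1ccc(-c2nnc3nnc(N4CCCC4)n3n2)cc1`, reaches only a limit of this assay, > 100000 nM.

Compound 3 holds the lowest of the two numbers, and compound 1 is nearest: a 1.2-fold lower number from compound 1 to compound 3 (0.07 log units; within the scatter). Compound 4, `Clc1ccccc1-c1nnc2nnc(N3CCCC3)nn12`, differs from compound 3 in one place: 2-chlorophenyl in place of cyclohexyl on an aromatic carbon. Going by the values given here, the only measured step, from methyl to cyclohexyl, stayed within the scatter, and no measured step places an aromatic ring here. Among the compounds with values here, compound 2, the one measured compound carrying an aromatic carbon ring at this spot, gave only a limit, (the limit of > 100000 nM in this assay, at which 1 of the 3 values shown sits). A higher number is therefore expected for compound 4, a 2.1-fold higher number from compound 3 to compound 4 (0.33 log units; beyond the scatter). Compound 4 is estimated at 80000 nM, within 30000 nM to 200000 nM.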

Compound 4, half-maximal inhibitory concentration: 29600 nM
For compound 4 the middle estimate is 2.7-fold (0.43 log units) above the measured one; the whole stated range lies above it.
By their numbers in this assay, from the lowest: compounds 4, 3 and 1 (each within the scatter of the next). At a limit, above all of these: compound 2.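

Going by these compounds alone, for the first time, an aromatic carbon ring stands at this place on the shared core, and the number does not move beyond the scatter, with a 1.3-fold lower number from compound 3 to compound 4 (0.11 log units; within the scatter) and a 1.5-fold lower number from compound 1 to compound 4 (0.18 log units; within the scatter). Methyl, cyclohexyl and 2-chlorophenyl thus give matching results in this assay, despite their different sizes and ring types. The core of compound 2 is not the shared core, so it is no guide to this place, and it gives only a limit: the limit of > 100000 nM in this assay, at which 1 of the 4 values shown sits.

Still open, from the compounds shown here alone, is whether the chlorine matters, which plain phenyl would test. Also open, going by these compounds, is whether a group such as an amine or a carboxylic acid here would shift the number beyond the scatter.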